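A few compounds are considered here, and "the series" means these few. Any claim that something is new, unique, unknown or untested is made for them only; others in the source may bear on it.

Measured in a functional assay on MCF7 cells (Homo sapiens) for antiproliferative activity, read by MTT assay, with a stated time of 72 h; on this read-out lower numbers stand for stronger inhibition and higher numbers for weaker inhibition:
- compound 1 `CC1=CC[C@H]2[C@H](CC[C@]2(C)O)C(C)(C)[C@@H]1CC[C@H]1[C@]2(C)CC[C@H](OC(=O)c3ccc(Cl)cc3)C(C)(C)O[C@H]2CC[C@@]1(C)O`: 24100 nM
- compound 2 `CC1=CC[C@H]2[C@H](CC[C@]2(C)O)C(C)(C)[C@@H]1CC[C@H]1[C@]2(C)CC[C@H](OC(=O)c3ccccc3C(F)(F)F)C(C)(C)O[C@H]2CC[C@@]1(C)O`: 19200 nM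

The two measured compounds cannot be separated, as a 1.3-fold lower number from compound 1 to compound 2 (0.10 log units; within the scatter) shows. Compound 3 `CC1=CC[C@H]2[C@H](CC[C@]2(C)O)C(C)(C)[C@@H]1CC[C@H]1[C@]2(C)CC[C@H](OC(=O)c3ccc(C(F)(F)F)c(F)c3)C(C)(C)O[C@H]2CC[C@@]1(C)O` carries 3-fluoro-4-(trifluoromethyl)phenyl in place of 2-(trifluoromethyl)phenyl on a carbonyl carbon. For the measured compounds named here, only one measured step bears on this change, and it is also an exchange of the group on a carbonyl carbon. That step stayed within the scatter, so no step beyond the scatter is expected in this assay. The expected step is a 1.0-fold higher number from compound 2 to compound 3 (0.02 log units; within the scatter). Compound 3 is estimated at 20000 nM, with an expected range of 10000 nM to 40000 nM.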

Compound 3, half-maximal inhibitory concentration: > 50000 nM
Compound 3: no number, only a limit; the forecaster's own chance of this, stated with the estimate: 10%; middle value at least 2.5-fold (0.39 log units) away from the limit.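

In this assay compound 3 gives > 50000 nM, which is a limit of the assay and not a number. The group on the carbonyl carbon is therefore not indifferent: 3-fluoro-4-(trifluoromethyl)phenyl gives an at least 2.6-fold higher number from compound 2 to compound 3 (0.41 log units; beyond the scatter) and an at least 2.0-fold higher number from compound 1 to compound 3 (0.31 log units; beyond the scatter), whereas the earlier exchange stayed within the scatter. Both steps are minimum sizes, and their full extent remains unknown: the limit of > 50000 nM in this assay, at which 1 of the 3 values shown sits.

From the compounds shown here alone, whether 4-(trifluoromethyl)phenyl without the fluorine would behave like compound 3 stays open. So does the effect of an amine on the phenyl group, or of a longer chain in its place.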